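Methoxy in Place of Trifluoromethyl on a Lactone Styrene

This account rests on a few compounds, and the source may have more. Where it says the series, first, only, none or still open, it means among the compounds named here.

Compound 2 `O=C1C=CCC(/C=C/c2ccc(C(F)(F)F)cc2)O1` gives 477 uM in a functional assay on NCI-H460 cells (Homo sapiens) for inhibition, read by sulforhodamine B assay, with a stated time of 48 h; on this read-out higher numbers stand for weaker inhibition of growth and lower numbers for stronger inhibition of growth. Compound 1 `COc1ccc(/C=C/c2cc(=O)cco2)cc1`, built on a different core, gives 606 uM in this assay, and the two numbers fall within the usual scatter of each other. Compound 3 `COc1ccc(/C=C/C2CC=CC(=O)O2)cc1` differs from compound 2 in one place: methoxy in place of trifluoromethyl on an aromatic carbon. Going by the values given here, no measured pair separates this change on its own. Compound 3 is expected to show a step of a 1.2-fold higher number from compound 2 to compound 3 (0.06 log units; within the scatter) in this assay, no larger than the scatter, since the methoxy-bearing compound 1 gives 606 uM. Compound 3 is therefore estimated at 550 uM, within 250 uM to 1200 uM.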

Compound 3, concentration for growth inhibition (reported as GI): 28.3 uM
Beside the measured number, compound 3's estimate is 19-fold (1.29 log units) above it, and the stated range ends above it.
By their numbers in this assay, from the lowest: compound 3; then compounds 2 and 1 (each within the scatter of the next).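

In this assay methoxy in place of trifluoromethyl gives a 17-fold lower number from compound 2 to compound 3 (1.23 log units; beyond the scatter) on the shared core, the first large step seen among these compounds. It shows that growth inhibition on this core depends strongly on the group at this aromatic carbon. No measurement on hand explains the size of this step. Going by these compounds alone, with only two groups compared here, it remains open whether a hydroxyl, an amine or an ethoxy group would match methoxy at this place. Going by these compounds, whether the same change carries over to the core of compound 1 also stays open.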